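The source may report more compounds than this note shows. Statements on the series, on what has been measured and on what is new or still open speak of the compounds shown alone.

Compound 3 `O=C(CCCCCCc1ccccc1)c1ncc(C(=O)C(F)(F)F)o1` sits second highest of the three numbers recorded in an assay (Rattus norvegicus) for inhibition of Fatty-acid amide hydrolase 1 (Homo sapiens); on this read-out higher numbers stand for weaker inhibition and lower numbers for stronger inhibition: compound 3 gives 4 nM, while compound 1 `NC(=O)c1ccc(-c2cnc(C(=O)CCCCCCc3ccccc3)o2)cc1` gives 10 nM and compound 2 `COc1ccnc(-c2cnc(C(=O)CCCCCCc3ccccc3)o2)c1` gives 0.8 nM. The step of a 2.5-fold lower number from compound 1 to compound 3 (0.40 log units; beyond the scatter) and the step of a 5.0-fold higher number from compound 2 to compound 3 (0.70 log units; beyond the scatter) both alter the group on the aromatic carbon of the shared core, as does a 13-fold lower number from compound 1 to compound 2 (1.10 log units; beyond the scatter). Compound 4 `O=C(CCCCCCc1ccccc1)c1ncc(C(=O)N2CCOCC2)o1` differs from compound 3 elsewhere: morpholin-4-yl in place of trifluoromethyl on a carbonyl carbon. Among the measured compounds shown here, no measured step touches that carbonyl carbon, so none bears directly on this change, and the expectation rests on the spread already seen. A modest rise of the number is expected for compound 4, with a 7.5-fold higher number from compound 3 to compound 4 (0.88 log units; beyond the scatter), and its value in this assay is estimated at 30 nM, within 5 nM to 200 nM.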

Compound 4, inhibition constant: 24 nM
Beside the measured number, compound 4's estimate is 1.3-fold (0.10 log units) above it, and the stated range covers the measured number.
By their numbers in this assay, from the lowest: compound 2; then compound 3; then compound 1; then compound 4.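

In this assay there is a 6.0-fold higher number from compound 3 to compound 4 (0.78 log units; beyond the scatter) when the group on the carbonyl carbon changes, so the number depends on this group as well as on the group on the aromatic carbon of the shared core. The (morpholin-4-yl)carbonyl group also gives the highest number of the four, with a 2.4-fold higher number from compound 1 to compound 4 (0.38 log units; beyond the scatter) against the 4-carbamoylphenyl group and a 30-fold higher number from compound 2 to compound 4 (1.48 log units; beyond the scatter) against the 4-methoxypyridin-2-yl group. Nothing shown accounts for these steps.

The compounds shown leave open whether the ring of the morpholin-4-yl group matters, as an open-chain dimethylamino group on the same carbonyl carbon would test. They also leave open how a methoxy group or a hydroxyl group there would compare.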